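A few compounds are considered here, and "the series" means these few. Any claim that something is new, unique, unknown or untested is made for them only; others in the source may bear on it.

Within the data shown here, in an assay on isolated protein for inhibition of coagulation factor X (Oryctolagus cuniculus), tested at 1 uM (on this read-out lower numbers stand for less inhibition and higher numbers for more inhibition at the one concentration tested (going by the name of the read-out)), compound 1 `O=C1[C@@H](NS(=O)(=O)c2cc3cccnc3s2)CCN1CCNc1ccncc1` gives 23%, which places it second highest of the three numbers measured so far: compound 2 `O=C1[C@@H](NS(=O)(=O)c2ccc(-c3ccccn3)s2)CCN1Cc1cc2c[nH]ccc-2n1` gives 11%, a number lower beyond the scatter, while compound 3 `Cc1c(S(=O)(=O)N[C@H]2CCN(Cc3cc4[nH]cccc-4n3)C2=O)sc2ccc(Cl)cc12` gives 40%, a number higher beyond the scatter. Compound 4 `O=C1[C@@H](NS(=O)(=O)c2cc3cccnc3s2)CCN1Cc1cc2c[nH]ccc-2n1` has not yet been measured in this assay. It differs from compound 1 in one place: a group of 9 heavy atoms (7 carbon, 2 nitrogen; one five-membered aromatic ring with 1 hetero atom, one six-membered aromatic ring with 1 hetero atom) in place of a group of 8 heavy atoms (6 carbon, 2 nitrogen; one six-membered aromatic ring with 1 hetero atom), on a saturated chain carbon bound to an amide-type nitrogen in a ring. Compound 2 and compound 3 both carry the group that enters, each with a different remainder, and their numbers lie on either side of compound 1. Among the measured compounds shown here, no measured step covers this exact change, so the step is expected to be modest, a number 1 percentage points higher from compound 1 to compound 4 (within the scatter), and not clearly beyond the scatter in either direction. Compound 4 is therefore estimated at 24%, within a range from 8% to 45%.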

Compound 4, a percentage reported as inhibition, at one concentration (the size of the read-out at that concentration, not a potency): 18%
Estimate against measurement, compound 4: 6 percentage points above, and the stated range covers the measured number.
By their numbers in this assay, from the lowest: compounds 2, 4 and 1 (each within the scatter of the next, the first and the last beyond it); then compound 3.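

At the saturated chain carbon bound to an amide-type nitrogen in a ring, replacing ((pyridin-4-yl)amino)methyl with the group bearing one five-membered and one six-membered aromatic ring gives a number 5 percentage points lower from compound 1 to compound 4 (within the scatter) in this assay. With the rest of the molecule held constant, this first direct comparison at this position shows no difference beyond the scatter between the two groups. No available evidence bears on this result. On these data alone, it remains open whether a primary amine on a longer chain, or a carboxylic acid, at this position would shift the read-out beyond the scatter.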